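Dropping the Chloro Substituent: An Expectation for Compound 3

A few compounds are considered here, and "the series" means these few. Any claim that something is new, unique, unknown or untested is made for them only; others in the source may bear on it.

Of the compounds shown here, two have been tested so far. Compound 1 `O=C(O)CCC1=C(c2ccc(Cl)cc2)NC(=S)NC1c1ccccc1O` was examined in a functional assay on the whole organism (strain Albino) for inhibition, with Rattus norvegicus as the target, with stated times of 1 h and 2 h, at a dose of 20 mg/kg by the oral route (on this read-out higher numbers stand for more inhibition at the one dose given (going by the name of the read-out) and lower numbers for less inhibition), where compound 1 gives 14.7%. Its companion compound 2 `COc1cc(C2NC(=S)NC(c3ccc(C)cc3)=C2CCC(=O)O)cc(OC)c1OC` in this assay gives 14.2%. These two numbers lie within the scatter of each other, so neither compound can be placed above the other; compound 1 stands alongside compound 2 among the two values known.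

Compound 3 `O=C(O)CCC1=C(c2ccccc2)NC(=S)NC1c1ccccc1O` is not yet measured. It differs from compound 1 by hydrogen in place of chloro on an aromatic carbon. Among the compounds with values here, the two measured compounds share no single-point difference, so no measured step guides this change. With the two known values so close, the change is expected to shift the read-out little, a number 2.7 percentage points lower from compound 1 to compound 3 (within the scatter), in neither direction beyond the scatter. Compound 3 is therefore estimated to give 12% in this assay, within a range from 3% to 25%.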

Compound 3, a percentage reported as inhibition, in the whole organism at one dose (the size of the read-out at that dose, not a potency): 28.6%
Estimate against measurement, compound 3: 16.6 percentage points below; the whole stated range lies below it.
By their numbers in this assay, from the lowest: compounds 2 and 1 (each within the scatter of the next); then compound 3.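

In this assay, within the data shown here, the change from 4-chlorophenyl to phenyl gives the only step that can be read at a single place, a number 13.9 percentage points higher from compound 1 to compound 3 (beyond the scatter). This shows that the aromatic carbon para to a large group is not a silent position: with hydrogen in place of chloro, inhibition at the one dose given rises beyond the scatter, though this rests on one pair of compounds alone. The data at hand offer no explanation for this rise.

As far as these compounds go, whether a fluoro group or an amine on that same aromatic carbon would give a number nearer compound 1 or compound 3 stays open. From the compounds shown here alone, it is also open whether the same change would have a similar effect on a compound with other groups elsewhere on the shared core, as this single pair cannot show it.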